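Lengthening a Side Chain on Compound 1

The compounds below may be only part of what the source reports. "The series", "measured", "known", "first", "only" and "open" are said of these compounds alone.

Measured so far:
compound 1 `CC(C)=CCOc1cc(=O)n(CCCO)c2c1CC(CC=C(C)C)C(C)(C)C2`: 20.7%
compound 2 `CC(C)=CCC1Cc2c(OC(=O)Nc3ccccc3F)cc(=O)n(CCCO)c2CC1(C)C`: 52.3%

In a functional assay on PANC-1 cells (Homo sapiens) for inhibition, read by MTT assay, with a stated time of 24 h, tested at 10 uM (on this read-out higher numbers stand for more inhibition at the one concentration tested (going by the name of the read-out) and lower numbers for less inhibition), compound 1 gives 20.7%, the lower of the two numbers. Compound 2 gives 52.3%, and the step of a number 31.6 percentage points higher from compound 1 to compound 2 (beyond the scatter) is large. Compound 3 `CC(C)=CCC/C(C)=C/CC1Cc2c(OCC=C(C)C)cc(=O)n(CCCO)c2CC1(C)C` differs from compound 1 by 3-methylbut-2-en-1-yl in place of hydrogen on a saturated chain carbon bound to a double-bonded chain carbon, so that 3-methylbut-2-en-1-yl becomes 3,7-dimethylocta-2,6-dien-1-yl. Among the compounds with values here, the only measured step changes the group on the ring oxygen and does not bear on this chain; no measured step speaks to it. No change beyond the scatter is therefore expected. Compound 3 is estimated at 22%, between 8% and 40%, a step of a number 1.3 percentage points higher from compound 1 to compound 3 (within the scatter).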

Compound 3, a percentage reported as inhibition, at one concentration (the size of the read-out at that concentration, not a potency): 30.3%
Compound 3: middle estimate off by 8.3 percentage points, on the low side; the range from low to high includes it.
By their numbers in this assay, from the lowest: compounds 1 and 3 (each within the scatter of the next); then compound 2.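

Putting 3-methylbut-2-en-1-yl in place of hydrogen on a saturated chain carbon bound to a double-bonded chain carbon gives, in this assay, a number 9.6 percentage points higher from compound 1 to compound 3 (within the scatter). This position therefore carries the longer 3,7-dimethylocta-2,6-dien-1-yl chain, with its 5 added carbons, without a shift beyond the usual scatter. No measurement at hand explains this result.

Still open, on these data alone, is whether an amine or a carboxylic acid at the end of this chain would change the reading. Also open, as far as these compounds go, is how a chain longer than 3,7-dimethylocta-2,6-dien-1-yl would read.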